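Fluoro in place of acetamido on the aromatic ring

The source may hold more compounds than are shown below. What is called first, only, known or untested is meant among the compounds shown, and "the series" means these compounds.

In an ADME assay on L929 cells (Mus musculus) for cytotoxicity, read by resazurin assay, with a stated time of 96 h (on this read-out lower numbers stand for higher toxicity in this test and higher numbers for lower toxicity in this test), compound 1 `NC(=S)N/N=C(\COc1ccccc1)c1ccc(Br)cc1` gives 54900 nM, with compound 2 `CC(=O)Nc1ccc(OC/C(=N\NC(N)=S)c2ccc(Br)cc2)cc1` at 94900 nM as the second reading. For the measured compounds named here, compound 2 therefore has compound 1 as its only neighbour on the scale, and the two values lie within the scatter of each other, so neither can be ranked above the other.

Compound 3 `NC(=S)N/N=C(\COc1ccc(F)cc1)c1ccc(Br)cc1` carries fluoro in place of acetamido on an aromatic carbon, a change counted as fluoro in place of acetamido on an aromatic carbon and located para to a large group. Going by the values given here, no compound with fluoro has been measured yet, so the basis for any forecast is thin. Among the compounds with values here, the one measured step that bears on this change is a 1.7-fold higher number from compound 1 to compound 2 (0.24 log units; within the scatter) with acetamido in place of hydrogen on an aromatic carbon, and it stays within the scatter. On that evidence, no step beyond the scatter is expected in this assay when acetamido leaves. The estimate is a 1.6-fold lower number from compound 2 to compound 3 (0.21 log units; within the scatter) as the expected step, which remains within the scatter. For compound 3 the estimated value is 58000 nM with an expected range from 25000 nM to 130000 nM around it.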

Compound 3, half-maximal cytotoxic concentration: 52300 nM
Compound 3: the middle estimate sits 1.1-fold (0.04 log units) above what was measured; measured number inside the range.
By their numbers in this assay, from the lowest: compounds 3, 1 and 2 (each within the scatter of the next).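

In this assay, fluoro in place of acetamido on an aromatic carbon, para to a large group, gives a 1.8-fold lower number from compound 2 to compound 3 (0.26 log units; within the scatter) and fluoro in place of hydrogen at that same carbon gives a 1.0-fold lower number from compound 1 to compound 3 (0.02 log units; within the scatter) (both steps lie within the scatter). The position now carries three different substituents, hydrogen, the acetamido group of 4 heavy atoms and the single fluorine atom, and compounds 1, 2 and 3 cannot be ranked against one another, so neither removing acetamido nor adding fluoro has produced a step beyond the scatter in this test. No measurement is at hand that would explain this flat result. The compounds shown leave open whether a carboxylic acid, an amine or a longer alkoxy chain at this aromatic carbon would shift the number beyond the scatter, since all three substituents here fall within it. They also leave open how far the number depends on the rest of the shared core, as compounds 1, 2 and 3 differ only at this one place.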